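The source may report more compounds than this note shows. Statements on the series, on what has been measured and on what is new or still open speak of the compounds shown alone.

Of the compounds shown here, three have so far been measured in an assay on U2OS cells for activation of nuclear factor erythroid 2-related factor 2 (Homo sapiens), read by beta-arrestin recruitment, with a stated time of 6 h; on this read-out lower numbers stand for an effect already at smaller amounts and higher numbers for an effect only at larger amounts of compound. Compound 1 `O=S(=O)(/C=C/c1ccccn1)c1cccc(F)c1` gives 1680 nM. Compound 2 `O=S(=O)(/C=C/c1ccc(Cl)cn1)c1cccc(F)c1` differs from compound 1 in a single place, (chloro in place of hydrogen on an aromatic carbon), and in this assay compound 2 gives 2500 nM; the step is a 1.5-fold higher number from compound 1 to compound 2 (0.17 log units; within the scatter). Compound 3 `O=S(=O)(/C=C/c1ccccn1)c1ccc(F)cc1` has the same atoms as compound 1 joined differently; the difference between the two cores is not broken down here. In this assay compound 3 gives 3100 nM, a number within the scatter of both compound 1 and compound 2, so no order among the three compounds can be read from these values.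

Compound 4 `O=S(=O)(/C=C/c1cccc(Cl)n1)c1ccc(F)cc1` has not yet been measured. It differs from compound 3 by chloro in place of hydrogen on an aromatic carbon. This is the same kind of change as that between compound 1 and compound 2, but not the same change: in compound 2 the chloro sits two atoms from the ring nitrogen and para to a large group, whereas in compound 4 it sits next to the ring nitrogen and meta to a large group. With one earlier example only, a step of similar size is expected; beside a 1.5-fold higher number from compound 1 to compound 2 (0.17 log units; within the scatter), the estimated step is a 1.4-fold higher number from compound 3 to compound 4 (0.13 log units; within the scatter). This expectation rests on compound 3 giving 3100 nM and on the earlier step lying within the scatter. Compound 4 is therefore expected to give about 4200 nM in this assay, with a likely range from 2000 nM to 9000 nM.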

Compound 4, half-maximal effective concentration: 2790 nM
Compound 4: middle estimate off by 1.5-fold (0.18 log units), on the high side; the measured number falls inside the stated range.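

In this assay, chloro in place of hydrogen on an aromatic carbon gives a 1.1-fold lower number from compound 3 to compound 4 (0.05 log units; within the scatter), so on the core of compound 3, as on the core of compound 1, this change leaves the number within the scatter. Set side by side, the two steps cannot be told apart: the same change on two cores in this assay, a 1.5-fold higher number (0.17 log units; within the scatter) from compound 1 to compound 2 and a 1.1-fold lower number (0.05 log units; within the scatter) from compound 3 to compound 4, 1.7-fold (0.22 log units) apart, within the scatter of two such steps. This shows that, across these two cores, the change has no size that can be read from the data, and it gives no sign that the core alters its outcome, but it does not show that the change carries over in the same way from one core to another, since both steps are too small to separate from the scatter, there are only two of them, and the chloro does not sit at the same place in compound 2 and compound 4.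

The compounds shown leave open whether an amine, a carboxylic acid or a longer chain in place of the chloro would give a number beyond the scatter of these values. They also leave open whether a chloro at one and the same place would give the same result on both cores.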